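The compounds below may be only part of what the source reports. "The series", "measured", "known", "first", "only" and "open" are said of these compounds alone.

Measured so far:
- compound 1, `Cc1cccc(CSc2cc(Cl)c(C)cc2S(=O)(=O)/N=C(\N)n2nccc2-c2ccccc2)c1`: in an ADME assay on HaCaT cells (Homo sapiens) for cytotoxicity, read by MTT assay, with a stated time of 72 h (a lower number here means a stronger inhibitor, a higher number a weaker inhibitor), compound 1 gives 10000 nM
- compound 2, `Cc1cc(S(=O)(=O)/N=C(\N)n2nccc2-c2ccccc2)c(SCc2ccccc2Cl)cc1Cl`: in this assay compound 2 gives 20000 nM

Within the data shown here, compound 2 holds the higher of the two numbers, yet the only step between them, a 2.0-fold higher number from compound 1 to compound 2 (0.30 log units; within the scatter), lies within the scatter, so the two cannot be told apart on these data. Compound 3, `Cc1cc(S(=O)(=O)/N=C(\N)n2nccc2-c2ccccc2)c(SCc2ccc(Cl)cc2)cc1Cl`, has not yet been measured. It differs from compound 2 in one place: 4-chlorophenyl in place of 2-chlorophenyl on a saturated chain carbon bound to a sulfur. Among the measured compounds shown here, only one measured step touches the same place, a 2.0-fold higher number from compound 1 to compound 2 (0.30 log units; within the scatter), and that one stayed within the scatter. Nothing measured here shows that exchanging one chlorophenyl for another moves the read-out, so no step beyond the scatter is expected in this assay. The expected step is a 1.3-fold lower number from compound 2 to compound 3 (0.12 log units; within the scatter), within the scatter. Compound 3 is accordingly estimated at 15000 nM, with a range from 5000 nM to 50000 nM.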

Compound 3, half-maximal inhibitory concentration: 12000 nM
Compound 3: the middle estimate sits 1.3-fold (0.10 log units) above what was measured, and the stated range covers the measured number.
By their numbers in this assay, from the lowest: compounds 1, 3 and 2 (each within the scatter of the next).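

In this assay, placing the chlorine differently on the ring, with 4-chlorophenyl in place of 2-chlorophenyl on a saturated chain carbon bound to a sulfur, gives a 1.7-fold lower number from compound 2 to compound 3 (0.22 log units; within the scatter) and so has no effect that these data can resolve. Among these compounds, the second comparison, 4-chlorophenyl in place of 3-methylphenyl, gives a 1.2-fold higher number from compound 1 to compound 3 (0.08 log units; within the scatter) and also stays within the scatter, so all three groups at this place now read alike, where before only one pair could be compared. No outside evidence bears on this result.

All three compounds carry a substituted phenyl ring held on the same one-carbon link to the sulfur, so this place has been tested only narrowly. From the compounds shown here alone, whether an amine, a carboxylic acid or a longer chain there would move the number beyond the scatter remains open.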